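This account rests on a few compounds, and the source may have more. Where it says the series, first, only, none or still open, it means among the compounds named here.

Compound 1 `O=C(NC(=S)NNc1ncnc2ccccc12)c1ccc(C(F)(F)F)cc1` gives 7920 nM in a functional assay on KB cells (Homo sapiens) for cytotoxicity, read by MTT assay, with a stated time of 72 h; a lower number here means a stronger inhibitor, a higher number a weaker inhibitor. Compound 2 `COc1cc2ncnc(NNC(=S)NC(=O)c3ccc(F)cc3)c2cc1OC` gives 4530 nM. Compound 3 `Cc1ccc(C(=O)NC(=S)NNc2ncnc3ccccc23)cc1` gives 10100 nM.

Compound 2 has the lowest number of the three. Its gap to compound 1 is within the scatter, so the two cannot be ordered; only its gap to compound 3 lies beyond the scatter.

Compound 4 `COc1cc2ncnc(NNC(=S)NC(=O)c3ccccc3Cl)c2cc1OC` has not yet been measured. It differs from compound 2 in one place: 2-chlorophenyl in place of 4-fluorophenyl on a carbonyl carbon. Going by the values given here, no measured step changes a halogen on this ring, so nothing bears on it directly. Among the compounds with values here, the only single-point step available, a 1.3-fold higher number from compound 1 to compound 3 (0.11 log units; within the scatter), exchanges one group for another on the same benzoyl ring and stays within the scatter. Compound 1 and compound 2 differ in the core as well as in the ring, so their values show only that both sit close together. On this evidence a substituent exchange on the benzoyl ring is expected to move the number little, and the step of a 1.1-fold higher number from compound 2 to compound 4 (0.04 log units; within the scatter) is therefore expected to stay within the scatter, with no direction called. Compound 4 is estimated at 5000 nM in this assay, with a range from 2000 nM to 12000 nM.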

Compound 4, half-maximal inhibitory concentration: 3560 nM
For compound 4 the middle estimate is 1.4-fold (0.15 log units) above the measured one, and the stated range covers the measured number.
By their numbers in this assay, from the lowest: compounds 4, 2, 1 and 3 (each within the scatter of the next, the first and the last beyond it).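

With a 1.3-fold lower number from compound 2 to compound 4 (0.10 log units; within the scatter) in this assay, a second exchange on the benzoyl ring stays within the scatter, this time on the core shared by compound 2 and compound 4 rather than the core shared by compound 1 and compound 3, and with a halogen on both sides of the change. The exchange replaces the halogen and alters its place on the ring at once, so 4-fluorophenyl and 2-chlorophenyl cannot be told apart here, and the effect of each alteration alone cannot be read from this step. Nothing available bears on why the two groups give such close numbers.

Going by these compounds, the separate roles of the halogen and its place remain open, and 4-chlorophenyl and 2-fluorophenyl on this same core would divide them. Also open, on these data alone, is whether the number stays this close with plain phenyl on the carbonyl carbon, with an amine or a carboxylic acid on the ring, or with a longer chain in place of the ring.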